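A few compounds are considered here, and "the series" means these few. Any claim that something is new, unique, unknown or untested is made for them only; others in the source may bear on it.

Compound 3 `CC(=O)Nc1ccc2nc(NC(=O)C3CCCCC3)sc2c1` gives the highest number of the three measured compounds in a functional assay on WI-38 VA13 cells (Homo sapiens) for cytotoxicity (a higher number here means that more compound is needed for the effect, a lower number that less compound is needed), at 2.7 ug/mL. Compound 2 `O=C(Nc1ccc2nc(NC(=O)C3CCCCC3)sc2c1)c1cccc(F)c1` gives 0.64 ug/mL in this assay, and compound 1 `O=C(Nc1ccc2nc(NC(=O)C3CCCCC3)sc2c1)c1ccccc1C(F)(F)F` gives 0.024 ug/mL. Compound 4 `Cc1cc(C(=O)Nc2ccc3nc(NC(=O)C4CCCCC4)sc3c2)n(C)n1` differs from compound 3 by 1,3-dimethyl-1H-pyrazol-5-yl in place of methyl on a carbonyl carbon, so the acetyl becomes a (1,3-dimethyl-1H-pyrazol-5-yl)carbonyl. Going by the values given here, two measured steps bear on this: both times an aromatic ring on the carbonyl carbon was exchanged for methyl, the number rose, by a 4.2-fold higher number from compound 2 to compound 3 (0.63 log units; beyond the scatter) and by a 110-fold higher number from compound 1 to compound 3 (2.05 log units; beyond the scatter). Compound 4 puts an aromatic ring back onto that carbonyl carbon, so a lower number is expected, by a step of about a 5.4-fold lower number from compound 3 to compound 4 (0.73 log units; beyond the scatter). Compound 4 is therefore estimated at 0.5 ug/mL, within a range from 0.1 ug/mL to 2 ug/mL.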

Compound 4, half-maximal effective concentration: 0.12 ug/mL
Estimate against measurement, compound 4: 4.2-fold (0.62 log units) above; measured number inside the range.
By their numbers in this assay, from the lowest: compound 1; then compound 4; then compound 2; then compound 3.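

With a five-membered aromatic ring holding two hetero atoms on the carbonyl carbon, the number in this assay also falls, by a 23-fold lower number from compound 3 to compound 4 (1.35 log units; beyond the scatter), so the fall seen on replacing methyl with an aromatic ring is not limited to substituted phenyl rings. The choice of ring also matters, with a 5.3-fold lower number from compound 2 to compound 4 (0.73 log units; beyond the scatter) and a 5.0-fold higher number from compound 1 to compound 4 (0.70 log units; beyond the scatter). No evidence is available here to explain these differences. The compounds shown leave open how an unsubstituted phenyl ring, a saturated piperidine ring or a longer alkyl chain on this carbonyl carbon would compare.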